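Extending the chain between ester and nitrooxy group

The source may report more compounds than this note shows. Statements on the series, on what has been measured and on what is new or still open speak of the compounds shown alone.

Of the compounds shown here, three have been measured in a functional assay on M14 cells (Homo sapiens) for cytotoxicity, read by resazurin assay, with a stated time of 72 h; a higher number here means a weaker inhibitor, a lower number a stronger inhibitor. Compound 1 `O=C(/C=C/c1ccc(O)c(O)c1)OCc1c(-c2ccccc2)no[n+]1[O-]` gives 12500 nM in this assay. Compound 2 `COc1cc(/C=C/C(=O)OCCCCCO[N+](=O)[O-])ccc1OCCCCCO[N+](=O)[O-]` gives > 50000 nM in this assay, which is a limit and not a number. Compound 3 `COc1cc(/C=C/C(=O)OCCCCCO[N+](=O)[O-])ccc1O` gives 24500 nM in this assay. Among the two numbers shown, compound 3 stands highest; its nearest neighbour is compound 1, and the gap between them lies within the scatter of the method, so the two cannot be ordered. Within the data shown here, the one step that joins measured compounds, an at least 2.0-fold lower number from compound 2 to compound 3 (0.30 log units; that floor lies within the scatter), has a floor that itself lies within the scatter, and it concerns the oxygen on the aromatic ring, not the chain.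

Compound 4 `COc1cc(/C=C/C(=O)OCCCCCCO[N+](=O)[O-])ccc1O` differs from compound 3 in one place: (nitrooxy)methyl in place of nitrooxy on a saturated chain carbon, five bonds along the chain from an oxygen next to a carbonyl group. No measured step alters the length of this chain, so the data give no direction for the number to move; the only step shown touches a different part of the structure and is small. The expected step in this assay is a 1.1-fold lower number from compound 3 to compound 4 (0.05 log units; within the scatter), that is, no movement beyond the scatter. The estimate for compound 4 in this assay is 22000 nM, with a range from 9000 nM to 50000 nM.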

Compound 4, half-maximal inhibitory concentration: > 50000 nM
Compound 4 was reported as a limit (the forecaster's own chance of this, stated with the estimate: 25%); at least 2.2-fold (0.35 log units) between middle value and limit.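

Among these compounds, this is the first measured step at this place, on a saturated chain carbon, five bonds along the chain from an oxygen next to a carbonyl group. In this assay, replacing nitrooxy with (nitrooxy)methyl gives an at least 2.0-fold higher number from compound 3 to compound 4 (0.30 log units; that floor lies within the scatter), so the result points towards a higher number on extending the chain, although it does not establish a change beyond the scatter. The full size of the step cannot be read because it ends at a limit of the assay: the limit of > 50000 nM in this assay, at which 2 of the 4 values shown sit.

The compounds shown leave open how the number behaves with a shorter chain on the ester oxygen, such as 4-(nitrooxy)butyl or 3-(nitrooxy)propyl, and whether any longer chain would bring a value that can be read as a number. They also leave open whether the nitrooxy group itself matters at the end of the chain, as a hydroxyl group or an amine in its place on the same chain would show.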